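The source may report more compounds than this note shows. Statements on the series, on what has been measured and on what is new or still open speak of the compounds shown alone.

Measured compounds:
compound 1, `COCOc1cc(/C=C/C(=O)OCC(=O)Nc2ccc(OC)cc2)ccc1OCc1ccccc1` — > 200000 nM
compound 2, `COCOc1cc(/C=C/C(=O)OCC(=O)NN2CCOCC2)ccc1OCc1ccccc1` — 143000 nM

Compound 1 and compound 2 share one core and differ only on an amide-type nitrogen. For the measured compounds named here, in a functional assay on ECa-109 cells (Homo sapiens) for cytotoxicity, read by MTT assay, with a stated time of 72 h (on this read-out higher numbers stand for weaker inhibition and lower numbers for stronger inhibition), compound 2 gives 143000 nM, the sole number recorded for the series. Compound 1 reaches only a limit in this assay, > 200000 nM, which is a bound and not a number, as stated by the limit of > 200000 nM in this assay, at which 1 of the 2 values shown sits. Going by the values given here, the single measured step, an at least 1.3-fold lower number from compound 1 to compound 2 (0.14 log units; that floor lies within the scatter), has a floor that lies within the scatter, so it gives no firm direction.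

Compound 3 `COCOc1cc(/C=C/C(=O)OCC(=O)NCc2ccco2)ccc1OCc1ccccc1` differs from compound 2 by (furan-2-yl)methyl in place of morpholin-4-yl on an amide-type nitrogen. Among the compounds with values here, the change sits on the same amide-type nitrogen that the one measured step altered, and that step, an at least 1.3-fold lower number from compound 1 to compound 2 (0.14 log units; that floor lies within the scatter), stayed within the scatter; no step beyond the scatter is therefore expected in this assay. The expected step is a 1.0-fold higher number from compound 2 to compound 3 (0.02 log units; within the scatter). Compound 3 is estimated at 150000 nM, with a range from 60000 nM to 300000 nM, and a limit rather than a number remains a real possibility.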

Compound 3, half-maximal inhibitory concentration: > 200000 nM
Compound 3 ended at the assay's limit; the forecaster's own chance of this, stated with the estimate: 35%; at least 1.3-fold (0.12 log units) between middle value and limit.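

Replacing morpholin-4-yl with (furan-2-yl)methyl on the amide-type nitrogen gives an at least 1.3-fold higher number from compound 2 to compound 3 (0.14 log units; that floor lies within the scatter), so a second change at this position also fixes no direction. The 4-methoxyphenyl of compound 1 and the (furan-2-yl)methyl of compound 3 both end at a limit in this assay, which leaves the step between those two compounds unreadable. Morpholin-4-yl in compound 2 remains the only group on this nitrogen with a number rather than a limit, though that separation does not pass the scatter: the limit of > 200000 nM in this assay, at which 2 of the 3 values shown sit.

From the compounds shown here alone, whether a simple alkyl amine, a carboxylic acid or a longer chain on this nitrogen would give a step beyond the scatter stays open. Also open, going by these compounds, is whether any group at this position matters as much as changes elsewhere on the shared core.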